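The source may report more compounds than this note shows. Statements on the series, on what has been measured and on what is new or still open speak of the compounds shown alone.

In a functional assay on Jurkat cells (Homo sapiens) for cytotoxicity, read by luminescence and CellTiter-Glo, with a stated time of 3 days (on this read-out higher numbers stand for weaker inhibition and lower numbers for stronger inhibition), two compounds have values so far:

- compound 1 `Cc1cc(C#N)ccc1NC(=O)c1ccc2cccnc2c1O`: 270 nM
- compound 2 `O=C(Nc1ccc(C(F)(F)F)cc1)c1ccc(Br)cc1O`: 500 nM

For the measured compounds named here, compound 1 sits within the usual scatter of compound 2, the only other compound measured, so the two cannot be ranked against each other. The next compound to be tested is compound 3 `N#Cc1ccc(NC(=O)c2ccc3cccnc3c2O)c(Cl)c1`, which keeps the core of compound 1 and differs from it in one place: chloro in place of methyl on an aromatic carbon. This is chloro in place of methyl on an aromatic carbon, at a place ortho to a large group and meta to a cyano group. Going by the values given here, no two measured compounds differ in just one place, so the data give no direct guide to this change. In this assay no step beyond the scatter is expected, in either direction. The expectation starts from compound 1 at 270 nM as its only close reference. The expected change is a 1.0-fold lower number from compound 1 to compound 3 (0.02 log units; within the scatter) and stays within the scatter. For compound 3 the estimated value is 260 nM in an expected range from 90 nM to 750 nM when it is measured.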

Compound 3, half-maximal inhibitory concentration: 550 nM
For compound 3 the middle estimate is 2.1-fold (0.33 log units) below the measured one, within the range that was stated.
By their numbers in this assay, from the lowest: compounds 1, 2 and 3 (each within the scatter of the next, the first and the last beyond it).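

In this assay, for the compounds shown here, the exchange of methyl for chloro on an aromatic carbon, ortho to a large group and meta to a cyano group, gives the first comparison between two compounds that differ in one place: a 2.0-fold higher number from compound 1 to compound 3 (0.31 log units; beyond the scatter), a modest step that lies just beyond the usual scatter. This position on the core of compound 1 is therefore not indifferent to the exchange, even though the group that leaves and the group that enters each count 1 heavy atom, with no ring, no hydrogen-bond donors or acceptors and no net charge. Nothing measured on these compounds accounts for the step, so it stands here as an observation without an explanation.

On these data alone, the step speaks for this one exchange at this one place, so it remains open how a fluoro group, a methoxy group or an amine would stand there on the same core. As far as these compounds go, it also remains open whether the same exchange would give a step of similar size at another place on the ring or with a different group in place of the cyano group.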